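Cyclopropyl for Methyl on the Core of Compound 3

A few compounds are considered here, and "the series" means these few. Any claim that something is new, unique, unknown or untested is made for them only; others in the source may bear on it.

In an ADME assay on microsomes from liver (Rattus norvegicus), read by LC-MS, using NADPH, with a stated time of 30 min, tested at 1 uM (a higher number here means that more of the compound is left, a lower number that less of the compound is left), the three measured compounds gave the following numbers:

Compound 1 `C[C@H](Nc1nc(N)nc(N)c1C#N)c1cc2ccc(F)cn2c(=O)c1-c1ccccc1`: 88%
Compound 2 `Cc1cccc(-c2c([C@H](C)Nc3nc(N)nc(N)c3C#N)cc3ccc(F)cn3c2=O)c1`: 77%
Compound 3 `Cc1c([C@H](C)Nc2nc(N)nc(N)c2C#N)c(-c2ccccc2)c(=O)n2cc(F)ccc12`: 85%

Compound 3 differs from compound 1 and from compound 2 only within the scatter of this assay, so the three numbers cannot be ranked against each other. Compound 4 `C[C@H](Nc1nc(N)nc(N)c1C#N)c1c(-c2ccccc2)c(=O)n2cc(F)ccc2c1C1CC1` is obtained from compound 3 by the change (cyclopropyl in place of methyl on an aromatic carbon). Among the measured compounds shown here, two measured steps bear on it. The step of a number 3 percentage points lower from compound 1 to compound 3 (within the scatter) placed a methyl at this same carbon without a shift beyond the scatter, while the step of a number 11 percentage points lower from compound 1 to compound 2 (beyond the scatter) placed a methyl on another aromatic carbon and gave a modest drop. Both steps are small, and the change to compound 4 is of the same kind, a small carbon group on the same aromatic carbon, so the expected step of a number 5 percentage points lower from compound 3 to compound 4 (within the scatter) is small and at most a modest decrease. For compound 4 the number in this assay is therefore estimated at 80%, with a range from 65% to 92%.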

Compound 4, percent of the compound remaining: 84%
Beside the measured number, compound 4's estimate is 4 percentage points below it, and the stated range covers the measured number.
By their numbers in this assay, from the lowest: compounds 2, 4, 3 and 1 (each within the scatter of the next, the first and the last beyond it).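

In this assay, replacing methyl with cyclopropyl on this aromatic carbon leaves the number effectively unchanged, with the step of a number 1 percentage points lower from compound 3 to compound 4 (within the scatter). The step of a number 4 percentage points lower from compound 1 to compound 4 (within the scatter) shows that the same holds when cyclopropyl is set against hydrogen at this carbon. The earlier compounds showed this only for methyl, and the result extends it to a group of 3 heavy atoms with a three-membered ring, although nothing available explains why the number holds.

The compounds shown carry only carbon groups at this position, so it remains open whether an amine, a methoxy group or a longer chain would also leave the number within the scatter. From the compounds shown here alone, it is also open whether the modest drop seen with the step of a number 11 percentage points lower from compound 1 to compound 2 (beyond the scatter) would recur on the core of compound 4.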